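Benzimidazole Amides and Their Tolerance in Vero Cells

The source may hold more compounds than are shown below. What is called first, only, known or untested is meant among the compounds shown, and "the series" means these compounds.

Measured so far, in an ADME assay on Vero cells (Chlorocebus sabaeus) for cytotoxicity; a higher number here means that more compound is tolerated, a lower number that less compound is tolerated:
compound 1 `COc1ccc(-c2nc3c(C(=O)Nc4ccccc4F)cccc3[nH]2)cc1OC` gives 24.5 uM;
compound 2 `COc1ccc(-c2nc3c(C(=O)Nc4nc5ccccc5[nH]4)cccc3[nH]2)c(OC)c1OC` gives 29 uM;
compound 3 `COc1ccc(-c2nc3c(C(=O)Nc4ncc[nH]4)cccc3[nH]2)cc1OC` gives "not active" (no number reported).

Compound 1 and compound 2 each return a number in this assay, and the two values are close to one another. Going by the values given here, compound 3 stands apart: in this assay it was reported as not active, so no single number describes it, and no step from compound 3 can be sized.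

Compound 4 `COc1ccc(-c2nc3c(C(=O)Nc4nc5ccccc5[nH]4)cccc3[nH]2)cc1OC` differs from compound 3 in one place only, (1H-benzimidazol-2-yl in place of 1H-imidazol-2-yl on an amide-type nitrogen). Among the compounds with values here, no measured pair shows this change, so its size in this assay is unknown. Compound 2 carries the same 1H-benzimidazol-2-yl amide as compound 4 and returned a number, which is the nearest guide. On that basis compound 4 is expected to return a number in this assay in the range seen for compound 1 and compound 2.

The estimate for compound 4 in this assay is 27 uM, expected to fall between 10 uM and 70 uM.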

Compound 4, half-maximal toxic concentration: 51.8 uM
Estimate against measurement, compound 4: 1.9-fold (0.28 log units) below, and the stated range covers the measured number.
By their numbers in this assay, from the lowest: compounds 1, 2 and 4 (each within the scatter of the next, the first and the last beyond it).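

In this assay, compound 4, with 1H-benzimidazol-2-yl on the amide-type nitrogen, returns a number, whereas compound 3, with 1H-imidazol-2-yl there, was reported as not active, so the step between them cannot be read. Placing 1H-benzimidazol-2-yl on that nitrogen instead of 2-fluorophenyl gives a 2.1-fold higher number from compound 1 to compound 4 (0.33 log units; beyond the scatter), a modest step, and hydrogen in place of methoxy on an aromatic carbon gives a 1.8-fold higher number from compound 2 to compound 4 (0.25 log units; within the scatter), so that change does not separate the two compounds in this assay. No supporting measurement bears on these results.

The compounds shown leave open how a cyclohexyl group, a primary amine or a carboxylic acid would read on the amide-type nitrogen. They also leave open whether compound 3 would return a number with a longer chain on that nitrogen in place of 1H-imidazol-2-yl.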